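Changing the amide group on compound 2

The compounds below may be only part of what the source reports. "The series", "measured", "known", "first", "only" and "open" are said of these compounds alone.

For the measured compounds named here, in an ADME assay on MT4 cells (Homo sapiens) for cytotoxicity, read by MTT assay, with a stated time of 5 days (a higher number here means that more compound is tolerated, a lower number that less compound is tolerated), compound 2 `COc1cc2nc([S+]([O-])CC(=O)Nc3ccc(C)cc3)nc(Nc3c(Cl)cc(/C=C/C#N)cc3Cl)c2cc1OC` gives 32200 nM, the only exact number so far. Compound 1 `COc1cc2nc([S+]([O-])CC(=O)Nc3cccc(C#N)c3)nc(Nc3c(Cl)cc(/C=C/C#N)cc3Cl)c2cc1OC` gives >= 70300 nM, which is a limit of the assay and not a number. Compound 3 `COc1ccccc1NC(=O)C[S+]([O-])c1nc(Nc2c(Cl)cc(/C=C/C#N)cc2Cl)c2cc(OC)c(OC)cc2n1` differs from compound 2 on an amide-type nitrogen: 2-methoxyphenyl in place of 4-methylphenyl on an amide-type nitrogen. Going by the values given here, the only measured step at this place, an at least 2.1-fold lower number from compound 1 to compound 2 (0.33 log units; beyond the scatter), involves a different group and gives no direction for this swap, so no change beyond the scatter is expected. The expected result is a 1.0-fold lower number from compound 2 to compound 3 (0.00 log units; within the scatter). For compound 3 the estimate is 32000 nM, with an expected range of 13000 nM to 75000 nM.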

Compound 3, half-maximal cytotoxic concentration: > 204000 nM
Compound 3 was reported as a limit (the forecaster's own chance of this, stated with the estimate: 20%); middle value at least 6.3-fold (0.80 log units) from the limit.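

In this assay, the group on the amide-type nitrogen can also move the number upward: 2-methoxyphenyl in place of 4-methylphenyl gives an at least 6.3-fold higher number from compound 2 to compound 3 (0.80 log units; beyond the scatter). Compound 3 carries a limit of the assay, not a number: the limit of > 204000 nM in this assay, at which 1 of the 3 values shown sits. The step from compound 1 to compound 3 joins two limits and cannot be read.

Still open, as far as these compounds go, is whether the change goes with the methoxy group itself or with its ring position, which 2-methylphenyl or 4-methoxyphenyl on this nitrogen could help separate. From the compounds shown here alone, how a simple amine or a carboxylic acid at this place would read also stays open.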